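Fluorophenyl position shift in a hydroxyphenyl-pyridine series

This account rests on a few compounds, and the source may have more. Where it says the series, first, only, none or still open, it means among the compounds named here.

Measured compounds:
- compound 1, `Oc1cccc(-c2cc(-c3cccc(F)c3)cc(-c3ccccc3O)n2)c1`: > 50000 nM in a functional assay on T47D cells (Homo sapiens) for inhibition; on this read-out lower numbers stand for stronger inhibition and higher numbers for weaker inhibition
- compound 2, `Oc1ccc(-c2cc(-c3cccc(F)c3)cc(-c3ccccc3O)n2)cc1`: > 50000 nM in this assay
- compound 3, `Oc1ccc(-c2cc(-c3ccccc3F)cc(-c3cccc(O)c3)n2)cc1`: 6370 nM in this assay

For compound 1 the value > 50000 nM is a limit of this assay, not a number. For compound 2 the value > 50000 nM is likewise a limit. The step that the two limits leave unreadable from compound 1 to compound 2 therefore cannot be read. For the measured compounds named here, compound 3 thus stands as the only compound with a numerical result; the other two sit at the limit of > 50000 nM in this assay, at which 2 of the 3 values shown sit.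

The unmeasured compound 4, `Oc1ccc(-c2cc(-c3cccc(F)c3)cc(-c3cccc(O)c3)n2)cc1`, differs from compound 3 by 3-fluorophenyl in place of 2-fluorophenyl on an aromatic carbon. No measured step concerns the position of the fluorine on this ring: the single step shown changes the hydroxyphenyl group and is unreadable. Nothing among the shown values therefore supports a direction for this change, and a step of no more than the usual scatter is expected, so that compound 4 is estimated at 6000 nM with a range of 1800 nM to 25000 nM. The expected step from compound 3 is a 1.1-fold lower number from compound 3 to compound 4 (0.03 log units; within the scatter).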

Compound 4, half-maximal inhibitory concentration: 3510 nM
Compound 4: the middle estimate sits 1.7-fold (0.23 log units) above what was measured; the measured number falls inside the stated range.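

In this assay the fluorine position on this ring cannot be told apart between 2-fluorophenyl and 3-fluorophenyl: the step is a 1.8-fold lower number from compound 3 to compound 4 (0.26 log units; within the scatter). The hydroxyphenyl position carries the large steps, with the 2-hydroxyphenyl group replaced in both cases: an at least 14-fold lower number from compound 2 to compound 4 (1.15 log units; beyond the scatter), and an at least 14-fold lower number from compound 1 to compound 4 (1.15 log units; beyond the scatter). Both sizes are only lower bounds, and the step between compound 1 and compound 2 cannot be read, because those two compounds are limits of the assay and not numbers: the limit of > 50000 nM in this assay, at which 2 of the 4 values shown sit.

Open, from the compounds shown here alone, is whether a methoxy group, an amine or a carboxylic acid in place of the hydroxyl on either hydroxyphenyl group would keep a value like that of compound 4. Also open, going by these compounds, is what a plain phenyl, a 4-fluorophenyl or a chlorophenyl group does at the place opposite the ring nitrogen.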